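The source may hold more compounds than are shown below. What is called first, only, known or untested is meant among the compounds shown, and "the series" means these compounds.

Of the compounds shown here, two sharing one core have been tested in an ADME assay on L02 cells (Homo sapiens) for cytotoxicity, read by MTT assay, with a stated time of 24 h; on this read-out higher numbers stand for weaker inhibition and lower numbers for stronger inhibition. Compound 1 `N#Cc1ccc(S(=O)(=O)N2C/C(=C\c3ccccc3F)C(=O)/C(=C/c3ccccc3F)C2)cc1` gives 11000 nM. Compound 2 `O=C1/C(=C/c2ccc(F)cc2)CN(S(=O)(=O)c2ccccc2)C/C1=C\c1ccc(F)cc1` gives 18800 nM, which is the higher of the two numbers, but the gap between it and compound 1 lies within the scatter of the measurement, so the two values are best read as the same.

Compound 3 `CC(=O)Nc1ccc(S(=O)(=O)N2C/C(=C\c3ccc(F)cc3)C(=O)/C(=C/c3ccc(F)cc3)C2)cc1` differs from compound 2 in one place: acetamido in place of hydrogen on an aromatic carbon, para to a large group. Among the compounds with values here, no pair of measured compounds isolates this change, so there is no measured step to lean on. Within the data shown here, the only guide is that the two measured compounds, which differ from each other in two places, land within the scatter of one another in this assay, which suggests the core carries the read-out and decorations on the outer rings move it little. The step expected for compound 3 is therefore a 1.2-fold lower number from compound 2 to compound 3 (0.07 log units; within the scatter), in other words none beyond the scatter. Compound 3 is expected to give 16000 nM in this assay, with a range from 6500 nM to 40000 nM.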

Compound 3, half-maximal inhibitory concentration: 19400 nM
The estimate for compound 3 lay 1.2-fold (0.08 log units) below the measured number; measured number inside the range.
By their numbers in this assay, from the lowest: compounds 1, 2 and 3 (each within the scatter of the next).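

Going from phenyl to 4-acetamidophenyl gives a 1.0-fold higher number from compound 2 to compound 3 (0.01 log units; within the scatter), so compound 2 and compound 3 read as the same in this assay. Within the data shown here, this is the first comparison here that isolates a single place, and it shows that hydrogen on this aromatic carbon, para to a large group, can give way to acetamido, with its 4 heavy atoms, 1 hydrogen-bond donor and 1 hydrogen-bond acceptor, without a difference beyond the scatter. The earlier pair could not show this, since compound 1 and compound 2 differ in two places at once, and nothing measured here addresses why the read-out is the same for compound 2 and compound 3.

On these data alone, this single step covers one group in one place, so it remains open whether an amine, a carboxylic acid or a longer chain on the same carbon would also read the same as hydrogen. As far as these compounds go, the separate contributions of the nitrile in compound 1 and of the fluorine placement on its outer rings also remain open, as no single-place comparison isolates either of them.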